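This account rests on a few compounds, and the source may have more. Where it says the series, first, only, none or still open, it means among the compounds named here.

Compound 1, `CC(C)(C)c1ccc(C(=O)NCc2ccc(SC(F)(F)F)cc2)cc1`, is the reference point of this small set. In an assay on HeLa cells with Bile acid receptor (Homo sapiens) as the target, read by a luciferase reporter, with a stated time of 24 h (on this read-out higher numbers stand for an effect only at larger amounts of compound and lower numbers for an effect already at smaller amounts), compound 1 gives 0.4 nM, the lowest number among the three compounds measured. Compound 2, `Cc1cc(CNC(=O)c2ccc(C(C)(C)C)cc2)ccc1C(=O)O`, gives 160 nM in this assay, and compound 3, `Cc1ccc(C(=O)NCc2ccc(C(=O)O)cc2)cc1C`, gives 320 nM; both of these numbers lie well beyond the scatter from that of compound 1, so compound 1 is the most potent of the three.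

The step considered here leads from compound 1 to compound 4, `CC(C)Oc1ccc(CNC(=O)c2ccc(C(C)(C)C)cc2)cc1`, which has not yet been measured. The change is isopropoxy in place of (trifluoromethyl)sulfanyl on an aromatic carbon. Among the compounds with values here, no measured pair in the set shows this same exchange, so the size of the step cannot be read off from the data; it can only be judged from the change itself and from how far the other compounds fall from compound 1.

Given that compound 1 stands at 0.4 nM, an exchange of the group para to the large group is expected to move the number upward by a moderate amount, beyond the scatter but far short of the gap to compounds 2 and 3. Compound 4 is therefore estimated at 4 nM in this assay, in the range 0.8 nM to 40 nM, which corresponds to an expected step of a 10-fold higher number from compound 1 to compound 4 (1.00 log units; beyond the scatter).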

Compound 4, half-maximal effective concentration: 170 nM
The estimate for compound 4 lay 43-fold (1.63 log units) below the measured number; measured number above the stated range.
By their numbers in this assay, from the lowest: compound 1; then compounds 2, 4 and 3 (each within the scatter of the next).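

In this assay, isopropoxy in place of (trifluoromethyl)sulfanyl, on an aromatic carbon para to a large group, gives a 430-fold higher number from compound 1 to compound 4 (2.63 log units; beyond the scatter), so this single exchange has a large effect on the read-out. Within the data shown here, the earlier compounds contained no pair differing in one place, and this step is the first to show how much the number can change at this position while the rest of the core of compound 1 stays the same. The step is large even though the two groups match in their hydrogen-bond donors and acceptors and neither has a ring or a net charge, so these shared features do not separate compound 1 from compound 4.

Why the exchange moves the number so far remains open, as nothing measured here bears on the reason. From the compounds shown here alone, it is also open whether (trifluoromethyl)sulfanyl is unusual at this position or whether other groups placed there, such as trifluoromethyl, methoxy, a nitrile, an amine or a longer chain, would stay near compound 1 or fall closer to compound 4.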